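Fluoro to methyl on the central ring: cytotoxicity tolerance

The source may hold more compounds than are shown below. What is called first, only, known or untested is meant among the compounds shown, and "the series" means these compounds.

Measured compounds:
compound 1 `COC(=O)N[C@H](C(=O)N1C[C@@H](C)C[C@H]1c1ncc(-c2ccc(-c3ccc(-c4cc5[nH]c([C@@H]6C[C@H](C)CN6C(=O)[C@@H](NC(=O)OC)C(C)C)nc5s4)c(F)c3)cc2)[nH]1)C(C)C`: > 20000 nM (a limit)
compound 2 `COC(=O)N[C@H](C(=O)N1C[C@@H](C)C[C@H]1c1ncc(-c2ccc(-c3ccc(-c4cc5[nH]c([C@@H]6C[C@H](C)CN6C(=O)[C@@H](NC(=O)OC)C(C)C)nc5s4)cc3F)cc2)[nH]1)C(C)C`: 20000 nM
compound 3 `COC(=O)N[C@H](C(=O)N1C[C@@H](C)C[C@H]1c1ncc(-c2ccc(-c3ccc(-c4cc5[nH]c([C@@H]6C[C@H](C)CN6C(=O)[C@@H](NC(=O)OC)C(C)C)nc5s4)c(C)c3)cc2)[nH]1)C(C)C`: > 20000 nM (a limit)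

In an ADME assay on HuhET cells (Homo sapiens) for cytotoxicity, read by thymidine incorporation (a higher number here means that more compound is tolerated, a lower number that less compound is tolerated), compound 1 gives > 20000 nM, which is a limit of the assay and not a number. Compound 3 likewise gives > 20000 nM, again a limit. Going by the values given here, compound 2 gives 20000 nM, the only number among the three. Compound 3 arises from compound 1 by methyl in place of fluoro on an aromatic carbon; the change gives a step that the two limits leave unreadable from compound 1 to compound 3. Compound 2 has the same atoms as compound 1, joined differently; the difference between the two cores is not broken down here.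

Compound 4 `COC(=O)N[C@H](C(=O)N1C[C@@H](C)C[C@H]1c1ncc(-c2ccc(-c3ccc(-c4cc5[nH]c([C@@H]6C[C@H](C)CN6C(=O)[C@@H](NC(=O)OC)C(C)C)nc5s4)cc3C)cc2)[nH]1)C(C)C` has not yet been measured in this assay. It arises from compound 2 by methyl in place of fluoro on an aromatic carbon, the same change that leads from compound 1 to compound 3. The size of that step could not be read, because of the limit of > 20000 nM in this assay, at which 2 of the 3 values shown sit. The writer expects a step of no change at the digits printed from compound 2 to compound 4 (within the scatter) in this assay, resting on a step that the two limits leave unreadable from compound 1 to compound 3 and on (the limit of > 20000 nM in this assay, at which 2 of the 3 values shown sit). Compound 4 is therefore estimated at 20000 nM, between 10000 nM and 50000 nM, with a fair chance that only a limit is returned.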

Compound 4, half-maximal cytotoxic concentration: 19200 nM
Compound 4: the middle estimate sits 1.0-fold (0.02 log units) above what was measured; the range from low to high includes it.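

In this assay, methyl in place of fluoro gives a 1.0-fold lower number from compound 2 to compound 4 (0.02 log units; within the scatter), so on the core of compound 2 the change stays within the scatter. The same change on the other core, leading from compound 1 to compound 3, cannot be read, so the two steps cannot be set side by side, and nothing shows that the change carries over in size from one core to the other: the limit of > 20000 nM in this assay, at which 2 of the 4 values shown sit. The series therefore offers one readable step on one core, which fits a change that carries over but does not establish it.

The compounds shown leave open whether another group at this place, such as a chloro, a methoxy or an amine, would also stay within the scatter of compound 2 in this assay. Also open, from the compounds shown here alone, is what number compound 1 or compound 3 would give if either could be read beyond its limit.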